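Methoxycarbonyl to carboxy in the antiproliferative series

The source may report more compounds than this note shows. Statements on the series, on what has been measured and on what is new or still open speak of the compounds shown alone.

Measured so far in a functional assay on HT-29 cells (Homo sapiens) for antiproliferative activity; on this read-out higher numbers stand for weaker inhibition and lower numbers for stronger inhibition:
- compound 1 `COc1ccc(S(=O)(=O)N2CCc3cccc(Nc4ccc([N+](=O)[O-])cc4)c32)cc1` gives 191 nM
- compound 2 `COC(=O)c1ccc(Nc2cccc3c2N(S(=O)(=O)c2ccc(OC)cc2)CC3)cc1` gives 678 nM

Compound 2 holds the higher of the two numbers, and compound 1 is its nearest neighbour. Within the data shown here, the one measured step, methoxycarbonyl in place of nitro on an aromatic carbon, reads a 3.5-fold higher number from compound 1 to compound 2 (0.55 log units; beyond the scatter) and is the only evidence on this group. Among the measured compounds shown here, compound 3 `COc1ccc(S(=O)(=O)N2CCc3cccc(Nc4ccc(C(=O)O)cc4)c32)cc1` carries hydrogen in place of methyl on an oxygen next to a carbonyl group as its single change, hydrogen in place of methyl on an oxygen next to a carbonyl group, or methoxycarbonyl to carboxy. For the measured compounds named here, no measured step covers this exchange, so the evidence is indirect and the direction is a judgement. In this assay a modest or somewhat larger step towards a higher number is expected, starting from compound 2 at 678 nM as the reference. The estimated change is a 2.9-fold higher number from compound 2 to compound 3 (0.47 log units; beyond the scatter) overall. Compound 3 is estimated at 2000 nM with an expected range from 500 nM to 9000 nM for now.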

Compound 3, half-maximal inhibitory concentration: 2380 nM
Estimate against measurement, compound 3: 1.2-fold (0.08 log units) below; measured number inside the range.
By their numbers in this assay, from the lowest: compound 1; then compound 2; then compound 3.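

In this assay, hydrogen in place of methyl on an oxygen next to a carbonyl group gives a 3.5-fold higher number from compound 2 to compound 3 (0.55 log units; beyond the scatter), so methoxycarbonyl to carboxy now has a direct measured step. Carboxy in place of nitro on an aromatic carbon gives a 12-fold higher number from compound 1 to compound 3 (1.10 log units; beyond the scatter), a large step that places the three groups in the order nitro, methoxycarbonyl, carboxy from the lowest number to the highest, with each step beyond the scatter. Nothing available explains this order.

Going by these compounds, how a primary carboxamide, a nitrile or an amine on the same aromatic carbon would rank against these three groups remains open. On these data alone, it is also open whether an ethyl ester would read like methoxycarbonyl or whether the order would hold with a different sulfonyl substituent on the shared core.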